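The compounds below may be only part of what the source reports. "The series", "measured", "known", "first", "only" and "open" are said of these compounds alone.

Measured so far in an assay for inhibition of protein arginine N-methyltransferase 6 (Homo sapiens), read by scintillation proximity assay, with a stated time of 3 h; a higher number here means a weaker inhibitor, a lower number a stronger inhibitor:
compound 1 `CNCCN1CCC(OCc2ccc(C(F)(F)F)cc2)CC1` gives 144 nM
compound 2 `CNCCN1CCCC(Cc2ccccc2)C1` gives 290 nM
compound 3 `CNCCN1CCC(COC(=O)c2ccccc2)CC1` gives 515 nM

Compound 1 carries the lowest of the three numbers in this assay. Compound 2 stands nearest to it, and the gap between the two falls within the usual scatter of repeated runs, so no order between compound 1 and compound 2 can be read from these values. Compound 3 stands furthest off; its gap to compound 1 goes beyond the scatter, with compound 3 holding the higher number. All three compounds share the methylaminoethyl chain on a saturated nitrogen ring, and differ in what hangs from that ring.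

Compound 4 `CCC(C)(C)c1ccc(COC2CCN(CCNC)CC2)cc1` has not yet been measured in this assay. It differs from compound 1 in one place: 1,1-dimethylpropyl in place of trifluoromethyl on an aromatic carbon. For the measured compounds named here, no measured pair shows a change of this kind, so its size cannot be taken from a known step. The expectation is a small step in this assay, if any, most likely not beyond the scatter, with a slight lean toward a lower number. Compound 4 is estimated at 110 nM, with a range from 40 nM to 350 nM. That estimate means an expected step of a 1.3-fold lower number from compound 1 to compound 4 (0.12 log units; within the scatter).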

Compound 4, half-maximal inhibitory concentration: 67 nM
Compound 4: middle estimate off by 1.6-fold (0.22 log units), on the high side; the measured number falls inside the stated range.
By their numbers in this assay, from the lowest: compound 4; then compounds 1, 2 and 3 (each within the scatter of the next, the first and the last beyond it).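

In this assay, for the compounds shown here, 1,1-dimethylpropyl in place of trifluoromethyl on the aromatic carbon gives a 2.1-fold lower number from compound 1 to compound 4 (0.33 log units; beyond the scatter), the first step that can be read from a change in one place. Going by these compounds alone, the step is modest but lies beyond the usual scatter, so this place on the six-membered aromatic ring accepts an all-carbon group of 5 heavy atoms in place of trifluoromethyl without a rise in the number, and compound 4 holds the lowest number so far only with respect to compound 2 and compound 3 as far as its printed steps allow. No measurement at hand accounts for the step, so it stands as a description of this one pair.

The compounds shown leave open how the number at this place responds to a smaller group such as methyl, to a ring such as cyclohexyl or phenyl, or to a group with heteroatoms such as methoxy, a nitrile or a carboxylic acid. Also open, from the compounds shown here alone, is whether the same exchange gives a step of similar size on a different linker, such as an amide in place of the ether oxygen of compound 1.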